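Amide-nitrogen substituent and maximal response in the series

The source may report more compounds than this note shows. Statements on the series, on what has been measured and on what is new or still open speak of the compounds shown alone.

Two compounds of the series have been run in a functional assay on Right cardiac atrium for agonist activity at histamine H2 receptor (Cavia porcellus), with a stated time of 30 min, in the presence of a further agent that is not named here; a lower number here means a smaller maximal response, a higher number a larger maximal response. Compound 1 `CCCCCCNC(=O)/N=C(\N)NCCCc1sc(N)nc1C` gives 0.95 in this assay. Compound 2 `Cc1nc(N)sc1CCCN/C(N)=N/C(=O)NC(C)c1cccs1` gives 0.88 in this assay. Going by the values given here, on these numbers compound 2 holds the lower of the two figures, but the single step to it, a number 0.070 lower from compound 1 to compound 2 (within the scatter), lies within the scatter, so compound 1 and compound 2 cannot be separated on maximal response.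

Compound 3 `CCCCCNC(=O)/N=C(\N)NCCCc1sc(N)nc1C` has not been measured. It differs from compound 2 by pentyl in place of 1-(thiophen-2-yl)ethyl on an amide-type nitrogen. Among the compounds with values here, the only measured step that bears on this is the one from compound 1 to compound 2, which exchanged hexyl for 1-(thiophen-2-yl)ethyl on the same amide-type nitrogen and moved the maximal response by a number 0.070 lower from compound 1 to compound 2 (within the scatter), within the scatter. The present change runs in the reverse sense, and pentyl is a plain alkyl chain of the same kind as the hexyl of compound 1. No step beyond the scatter is therefore expected in this assay, with any movement more likely upward than downward. Compound 3 is expected to give 0.93 in this assay, within a range of 0.82 to 1.02. The expected step is a number 0.050 higher from compound 2 to compound 3 (within the scatter), which is within the scatter.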

Compound 3, intrinsic activity: the largest response reached, as a fraction of the reference agonist's: 0.78
For compound 3 the middle estimate is 0.15 above the measured one; measured number outside the range, below it.
By their numbers in this assay, from the lowest: compounds 3, 2 and 1 (each within the scatter of the next, the first and the last beyond it).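

Going by these compounds alone, the step a number 0.17 lower from compound 1 to compound 3 (beyond the scatter) is the first to pass the scatter, and it comes from hydrogen in place of methyl on a saturated chain carbon, five bonds along the chain from an amide-type nitrogen, so hexyl and pentyl are not interchangeable at this nitrogen in this assay. The step a number 0.10 lower from compound 2 to compound 3 (within the scatter) stays inside the scatter, as does the step a number 0.070 lower from compound 1 to compound 2 (within the scatter), so 1-(thiophen-2-yl)ethyl cannot be ranked against either plain alkyl chain on maximal response. Nothing measured here offers an explanation for this sensitivity to the alkyl chain.

Within the data shown here, two alkyl compounds fix only a single step of chain length, so it remains open whether a butyl chain or a heptyl chain would follow the same direction or whether hexyl is a special case. Also open, from the compounds shown here alone, is whether a 1-phenylethyl group or a thiophen-2-ylmethyl group on the same nitrogen would stay inseparable from compound 1 and compound 3, as 1-(thiophen-2-yl)ethyl does.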